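Aryl substituent swap in a T-type channel series

The source may hold more compounds than are shown below. What is called first, only, known or untested is meant among the compounds shown, and "the series" means these compounds.

Compound 1 `CCCc1nc(-c2ccccc2)c(CNCCN2CCN(c3ccccc3F)CC2)o1` and compound 2 `CCCc1nc(-c2ccccc2)c(CNCCN2CCN(c3ccccc3OC)CC2)o1` share one core; compound 3 `CCCc1nc(-c2ccccc2)c(CNCCCN2CCN(c3cccc(F)c3)CC2)o1` and compound 4 `CCCc1nc(-c2ccccc2)c(CNCCCN2CCN(c3cccc(OC)c3)CC2)o1` share another. How the core of compound 3 differs from that of compound 1 is not broken down here. In an assay on HEK293 cells for inhibition of Voltage-dependent T-type calcium channel subunit alpha-1G (Homo sapiens), read by fluorescence, tested at 10 uM (on this read-out lower numbers stand for less inhibition and higher numbers for more inhibition at the one concentration tested (going by the name of the read-out)), compound 1 gives 46.5% and compound 2 gives 39.7%. The change between them is methoxy in place of fluoro on an aromatic carbon, and it made a number 6.8 percentage points lower from compound 1 to compound 2 (within the scatter). In this assay compound 3 gives 68.9%, the highest of the three numbers. The change from compound 3 to compound 4 is methoxy in place of fluoro on an aromatic carbon. Within the data shown here, this is the same kind of change as the one from compound 1 to compound 2, but not the same: there the group sits ortho to a large group, here meta to a large group. The step from compound 3 to compound 4 is expected to be a number 6.9 percentage points lower from compound 3 to compound 4 (within the scatter), resting on the earlier a number 6.8 percentage points lower from compound 1 to compound 2 (within the scatter). Compound 4 is therefore estimated at 62%, between 46% and 78%.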

Compound 4, a percentage reported as inhibition, at one concentration (the size of the read-out at that concentration, not a potency): 36.4%
The estimate for compound 4 lay 25.6 percentage points above the measured number; measured number below the stated range.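

Methoxy in place of fluoro does not carry a fixed effect from one core to the other in this assay: the same change on two cores in this assay, a number 6.8 percentage points lower (within the scatter) from compound 1 to compound 2 and a number 32.5 percentage points lower (beyond the scatter) from compound 3 to compound 4, 25.7 percentage points apart, beyond the scatter of two such steps

On the core of compound 3 the step is a number 32.5 percentage points lower from compound 3 to compound 4 (beyond the scatter), so the inhibition seen with the 3-fluorophenyl group is not kept with the 3-methoxyphenyl group. This does not show what sets the gap between the two steps: the pairs differ in core and also in where the group sits, with the group in compound 3 and compound 4 meta to a large group, and two pairs cannot separate those factors.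

The compounds shown leave open how the 3-fluorophenyl to 3-methoxyphenyl change reads on the core of compound 1, which would test the core alone. They also leave open whether chloro, hydroxy or trifluoromethyl on the same aromatic carbon would track with fluoro or with methoxy on the core of compound 3.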